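A few compounds are considered here, and "the series" means these few. Any claim that something is new, unique, unknown or untested is made for them only; others in the source may bear on it.

Compound 1 `Cc1ccc(NC(=O)Nc2cccc(CNc3nccnc3Cl)c2)c(C)c1` is one of three compounds built on a shared core and tested in a functional assay on T-24 cells (Homo sapiens) for antiproliferative activity, read by MTT assay, with a stated time of 48 h; a lower number here means a stronger inhibitor, a higher number a weaker inhibitor. In this assay compound 1 gives 9230 nM, and compound 2 `O=C(Nc1ccc(C(F)(F)F)cc1)Nc1cccc(CNc2nccnc2Cl)c1` gives 4580 nM; these two numbers lie within the usual scatter of each other, so neither can be called the stronger inhibitor. For compound 3 `O=C(Nc1cccc(CNc2nccnc2Cl)c1)Nc1cccc2ccccc12`, this assay reports no number but a limit, > 40000 nM; this is the limit of > 40000 nM in this assay, at which 1 of the 3 values shown sits. Compound 4 `O=C(Nc1cccc(CNc2nccnc2Cl)c1)Nc1ccc(Cl)c(Cl)c1` has not yet been measured. It differs from compound 1 in a single place: 3,4-dichlorophenyl in place of 2,4-dimethylphenyl on an amide-type nitrogen. For the measured compounds named here, no measured pair isolates this change, so its size is open. Compound 2 sits close to compound 1, while compound 3 shows that a change on the same amide-type nitrogen can leave the number at the limit. The expected step from compound 1 to compound 4 is a 1.7-fold lower number from compound 1 to compound 4 (0.22 log units; within the scatter), within the scatter or only a little beyond it. For compound 4 the estimate in this assay is 5500 nM, with a range from 2000 nM to 16000 nM.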

Compound 4, half-maximal inhibitory concentration: 5210 nM
Estimate against measurement, compound 4: 1.1-fold (0.02 log units) above, within the range that was stated.
By their numbers in this assay, from the lowest: compounds 2, 4 and 1 (each within the scatter of the next). At a limit, above all of these: compound 3.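

In this assay, 3,4-dichlorophenyl in place of 2,4-dimethylphenyl on an amide-type nitrogen gives a 1.8-fold lower number from compound 1 to compound 4 (0.25 log units; within the scatter), so this exchange produces no change that can be told from the scatter. With compound 2, the three substituted phenyl groups on this nitrogen in compound 1, compound 2 and compound 4 now form a set whose numbers lie within the scatter of the next, whether the substituents are methyl, trifluoromethyl or chlorine. Compound 3 goes against this pattern, and its reading is a limit, not a number: the limit of > 40000 nM in this assay, at which 1 of the 4 values shown sits.

On these data alone, it remains open whether a plain phenyl, or a phenyl carrying an amine or a carboxylic acid, would move the number beyond the scatter. The compounds shown also leave open what a change elsewhere on the shared core would do.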